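Lengthening the Chain on Compound 3: What to Expect

The compounds below may be only part of what the source reports. "The series", "measured", "known", "first", "only" and "open" are said of these compounds alone.

Measured so far in a functional assay on HT-29 cells (Homo sapiens) for antiproliferative activity, read by sulforhodamine B assay, with a stated time of 48 h; a higher number here means a weaker inhibitor, a lower number a stronger inhibitor:
compound 1 `CC(C)C(=O)Nc1ccc(S(=O)(=O)Oc2ccccc2I)cc1` gives 13000 nM
compound 2 `CC(C)(C)C(=O)Nc1ccc(S(=O)(=O)Oc2ccccc2I)cc1` gives 9500 nM
compound 3 `CCNC(=O)Nc1ccc(S(=O)(=O)Oc2ccccc2I)cc1` gives 5300 nM

Compound 3 has the lowest number of the three. Its distance from compound 1 is beyond the scatter, a 2.5-fold lower number from compound 1 to compound 3 (0.39 log units; beyond the scatter), but its distance from compound 2 is not, a 1.8-fold lower number from compound 2 to compound 3 (0.25 log units; within the scatter), so compound 3 and compound 2 cannot be ranked against each other.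

Compound 4 `CCCCCNC(=O)Nc1ccc(S(=O)(=O)Oc2ccccc2I)cc1` differs from compound 3 by propyl in place of hydrogen on a saturated chain carbon, two bonds along the chain from an amide-type nitrogen. Within the data shown here, none of the measured steps touches this position. Among the measured compounds shown here, the only step that adds carbon to a saturated chain, a 1.4-fold lower number from compound 1 to compound 2 (0.14 log units; within the scatter), stayed within the scatter, and the other two steps exchange the whole group on the carbonyl carbon rather than extend a chain. There is therefore no ground in the measured compounds for expecting a step beyond the scatter in this assay in either direction.

Compound 4 is expected to give about 5000 nM in this assay, with a plausible range from 2000 nM to 13000 nM. The expected change is a 1.1-fold lower number from compound 3 to compound 4 (0.03 log units; within the scatter).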

Compound 4, half-maximal inhibitory concentration: 6600 nM
For compound 4 the middle estimate is 1.3-fold (0.12 log units) below the measured one, within the range that was stated.
By their numbers in this assay, from the lowest: compounds 3, 4, 2 and 1 (each within the scatter of the next, the first and the last beyond it).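

Lengthening ethylamino to pentylamino on the carbonyl carbon leaves the number in this assay within the scatter (a 1.2-fold higher number from compound 3 to compound 4 (0.10 log units; within the scatter)), so this position takes propyl in place of hydrogen without a readable gain or loss. The new compound also cannot be told apart from either amide (a 1.4-fold lower number from compound 2 to compound 4 (0.16 log units; within the scatter); a 2.0-fold lower number from compound 1 to compound 4 (0.29 log units; within the scatter)), although compound 3 stood beyond the scatter from compound 1, which shows how small these differences are and that the longer chain does not clearly preserve that separation. No measurement is available here that could explain this result.

As far as these compounds go, whether a still longer chain, such as decyl, would keep the number in this range remains open. So does the effect of a chain carrying an amine or a carboxylic acid at this position.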